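The source may hold more compounds than are shown below. What is called first, only, known or untested is meant among the compounds shown, and "the series" means these compounds.

Measured so far:
compound 1 `COc1ccc(CS(=O)(=O)/C=C/c2ccc(OC)c(OC)c2OC)cc1N` — 5950 nM
compound 2 `COc1cc(OC)c(/C=C/S(=O)(=O)Cc2ccc(OC)c(NC(C)=O)c2)c(OC)c1` — 350 nM

In a functional assay on MCF7 cells (Homo sapiens) for cytotoxicity, read by MTT assay, with a stated time of 72 h (a lower number here means a stronger inhibitor of growth, a higher number a weaker inhibitor of growth), compound 1 gives 5950 nM, the highest of the two numbers; compound 2 gives 350 nM, a gap beyond the usual scatter. Compound 3 `COc1ccc(CS(=O)(=O)/C=C/c2ccc(OC)c(OC)c2OC)cc1[N+](=O)[O-]` is not yet measured. It differs from compound 1 in one place: nitro in place of amino on an aromatic carbon. For the measured compounds named here, no measured pair shows this change, so its direction is unknown, and the step is expected to be small, a 1.2-fold lower number from compound 1 to compound 3 (0.08 log units; within the scatter), likely within the scatter. Compound 3 is therefore estimated at 5000 nM, in a range from 1500 nM to 15000 nM.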

Compound 3, concentration for 50% growth inhibition: > 30000 nM
Compound 3: no number, only a limit; the forecaster's own chance of this, stated with the estimate: 10%; middle value at least 6.0-fold (0.77 log units) from the limit.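

This position on the ring, ortho to a methoxy group, is not indifferent to what it carries. In this assay, nitro in place of amino gives an at least 5.0-fold higher number from compound 1 to compound 3 (0.70 log units; beyond the scatter), a change large enough to stand out from the scatter, so amino is clearly preferred to nitro here. From the compounds shown here alone, compound 3 gives > 30000 nM, which is a limit of the assay and not a number, so the full size of the loss is unknown.

The compounds shown leave open how a hydroxyl or a methylamino group on this carbon would compare with amino.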